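Dropping a Methyl: Expected Effect on Gastric Dose

The source may hold more compounds than are shown below. What is called first, only, known or untested is meant among the compounds shown, and "the series" means these compounds.

Measured compounds:
compound 1, `Cc1ccc(=S)n(CCC(=N)S)n1`, 100 mg/kg
compound 2, `C/N=C(\S)C(C)Cn1ncccc1=O`, 100 mg/kg

Both were tested in a functional assay on the whole organism (stomach) with Rattus norvegicus as the target; on this read-out lower numbers stand for an effect already at smaller amounts and higher numbers for an effect only at larger amounts of compound. Compound 1 gives 100 mg/kg and compound 2 gives 100 mg/kg; these two values lie within the usual scatter of each other, so compound 1 stands level with compound 2. Compound 3, `N=C(S)CCn1ncccc1=S`, has not yet been measured. It differs from compound 1 in one place: hydrogen in place of methyl on an aromatic carbon. For the measured compounds named here, no measured pair shows the effect of such a change, so there is no step to lean on. In this assay the step of no change at the digits printed from compound 1 to compound 3 (within the scatter) is expected, nothing beyond the scatter. Compound 3 is therefore estimated at 100 mg/kg, within 40 mg/kg to 250 mg/kg.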

Compound 3, dose for half-maximal effect: 100 mg/kg
Beside the measured number, compound 3's estimate shows no gap at the digits printed; the measured number falls inside the stated range.
By their numbers in this assay, from the lowest: compounds 1, 2 and 3 (each within the scatter of the next).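

For the compounds shown here, compound 1 and compound 3 form the only measured pair that differs in one place: in this assay, hydrogen in place of methyl on an aromatic carbon gives no change at the digits printed from compound 1 to compound 3 (within the scatter). In this one pair, then, the methyl on this carbon can go without the dose moving beyond the usual scatter. Nothing measured here offers an explanation for this result.

Still open, as far as these compounds go, is whether a group other than methyl or hydrogen on this carbon, such as an ethyl chain, an amine or a carboxylic acid, would also leave the dose unchanged.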